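An Oxan-4-yl Ether Tested Against a Weak Methoxy Lead

A few compounds are considered here, and "the series" means these few. Any claim that something is new, unique, unknown or untested is made for them only; others in the source may bear on it.

Compound 3 `COc1cc(F)c(F)c(-c2cc(F)c(OCCCC(=O)O)c(F)c2)c1` is the only one of the three measured compounds that gives a number in a functional assay on CHO cells for agonist activity at Free fatty acid receptor 1 (Homo sapiens), read by calcium flux; a higher number here means that more compound is needed for the effect, a lower number that less compound is needed: compound 3 gives 24400 nM. For compound 1 `CO[C@H]1C[C@H](Oc2cc(F)c(F)c(-c3cc(F)c(OCCCC(=O)O)c(F)c3)c2)C1` the read-out is a limit, > 100000 nM. For compound 2 `CO[C@H]1C[C@H](Oc2cc(F)c(F)c(-c3cc(F)c(SCCCC(=O)O)c(F)c3)c2)C1` the read-out is likewise a limit, > 100000 nM. The step that the two limits leave unreadable from compound 1 to compound 2 cannot be read, whereas an at least 4.0-fold lower number from compound 1 to compound 3 (0.61 log units; beyond the scatter) runs toward the smaller ether. Compound 4 `O=C(O)CCCOc1c(F)cc(-c2cc(OC3CCOCC3)cc(F)c2F)cc1F` goes the other way: oxan-4-yl in place of methyl on an oxygen on an aromatic ring. Because the limit of > 100000 nM in this assay, at which 2 of the 3 values shown sit, is where the bulkier ether of compound 1 sat, a larger ring on that oxygen is expected to raise the number again. Compound 4 is therefore expected to give a weaker result, the step being a 3.3-fold higher number from compound 3 to compound 4 (0.52 log units; beyond the scatter). For compound 4 the estimate is 80000 nM, between 25000 nM and 300000 nM, with a fair chance of only a limit.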

Compound 4, half-maximal effective concentration: > 100000 nM
Compound 4 ended at the assay's limit (the forecaster's own chance of this, stated with the estimate: 55%); at least 1.2-fold (0.09 log units) between middle value and limit.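

In this assay, the change from methoxy to (oxan-4-yl)oxy gives an at least 4.0-fold higher number from compound 3 to compound 4 (0.61 log units; beyond the scatter), so a second large ether on this oxygen, this one a six-membered ring with a ring oxygen, also loses the measurable response of compound 3. Compound 4 gives > 100000 nM, which is a limit, and the step from compound 1 to compound 4 cannot be read. Of the ethers shown at this position, only the methyl of compound 3 gives a number, and the rest sit at one value: the limit of > 100000 nM in this assay, at which 3 of the 4 values shown sit.

Going by these compounds, it remains open whether an ethyl or a hydroxy group on this position would give a lower number than compound 3. Also open, on these data alone, is whether any ring smaller than oxan-4-yl, such as a cyclopropyl, would stay clear of the limit.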